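The source may report more compounds than this note shows. Statements on the series, on what has been measured and on what is new or still open speak of the compounds shown alone.

Working notes on the series

Compound 1 `COc1cc(-c2cc(/C=C/C(=O)c3ccc(N)cc3)[nH]n2)cc(OC)c1OC` is measured in a functional assay on MOLT-4 cells (Homo sapiens) for inhibition, read by sulforhodamine B assay, with a stated time of 48 h (a lower number here means that less compound is tolerated, a higher number that more compound is tolerated), and gives only a limit there: compound 1 shows > 100000 nM. Compound 2 `COc1ccc(-c2cc(/C=C/C(=O)c3ccc(OC)c(OC)c3)[nH]n2)cc1` sits at a limit as well; in this assay compound 2 shows > 100000 nM. So both measured values are limits, not numbers, and the limit of > 100000 nM in this assay, at which 2 of the 2 values shown sit, is the whole of what is known; compound 1 therefore stands at the limit, with no ranking against compound 2 possible.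

Compound 3 `COc1cc(-c2cc(/C=C/C(=O)c3ccc(F)c(F)c3)[nH]n2)cc(OC)c1OC` remains to be measured in this assay. Its difference from compound 1 is 3,4-difluorophenyl in place of 4-aminophenyl on a carbonyl carbon. Within the data shown here, no step between measured compounds exists, so the size of the change from a 4-aminophenyl to a 3,4-difluorophenyl on the carbonyl carbon has no precedent here.

With two limits and nothing else, the expectation for compound 3 is a step of a number no higher from compound 1 to compound 3 (the limit leaves the size open), that is, no change beyond the scatter. Compound 3 is estimated at 100000 nM, with a range from 20000 nM to 300000 nM; a further limit rather than a number is the most likely outcome.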

Compound 3, concentration lethal to 50% of the cells: > 100000 nM
Compound 3: only a limit was reported; the forecaster's own chance of this, stated with the estimate: 65%; the middle value lies on the limit itself.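

In this assay compound 3 gives > 100000 nM, which is a limit and not a number. Among these compounds, no step from compound 1 to compound 3 can be read: the limit of > 100000 nM in this assay, at which 3 of the 3 values shown sit.

The compounds shown leave open what concentration any of them would need in this assay, and whether 3,4-difluorophenyl in place of 4-aminophenyl shifts the read-out at all.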